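The source may report more compounds than this note shows. Statements on the series, on what has been measured and on what is new or still open speak of the compounds shown alone.

Measured compounds in an ADME assay on HepG2 cells (Homo sapiens) for cytotoxicity, read by MTT assay, with a stated time of 48 h; on this read-out lower numbers stand for stronger inhibition and higher numbers for weaker inhibition:
compound 1 `CC(C)CN1C(=O)/C(=C/c2ccc([N+](=O)[O-])cc2)S/C1=N\c1ccccc1` gives > 100000 nM.
compound 2 `COc1ccc(/C=C2\S/C(=N\c3ccccc3)N(CC(C)C)C2=O)cc1` is recorded as "not determined" (no result reported).

The value for compound 1 is a limit of this assay, not a number. Compound 2 therefore stands nowhere on the numbers shown: no single figure exists for it, and the one other value in the set is that limit (the limit of > 100000 nM in this assay, at which 1 of the 2 values shown sits). For the measured compounds named here, no step between measured compounds can be drawn.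

Compound 3 `CC(C)CN1C(=O)/C(=C/c2ccccn2)S/C1=N\c1ccccc1` is the next member to be measured in this assay . Relative to compound 2 the change is pyridin-2-yl in place of 4-methoxyphenyl on a double-bonded chain carbon bound to a double-bonded ring carbon. Going by the values given here, because no measured step exists for this pair, the size of the step cannot be taken from the data; the expectation for this assay is no shift beyond the usual scatter, in either direction. Compound 3 is estimated at 80000 nM, with a range from 20000 nM to 200000 nM, and it is expected that this assay may again report only a limit.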

Compound 3, half-maximal inhibitory concentration: > 100000 nM
Compound 3 ended at the assay's limit (the forecaster's own chance of this, stated with the estimate: 60%); at least 1.2-fold (0.09 log units) between middle value and limit.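

No step can be read from compound 1 to compound 3 in this assay, since both values are limits and not numbers: the limit of > 100000 nM in this assay, at which 2 of the 3 values shown sit.

The compounds shown leave open how pyridin-2-yl and 4-nitrophenyl compare on the shared core in this assay, and where compound 2 stands.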